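Cytotoxicity Limits Across a Shared Sulfonamide Core

A few compounds are considered here, and "the series" means these few. Any claim that something is new, unique, unknown or untested is made for them only; others in the source may bear on it.

Measured so far:
compound 1, `Cc1ccc(S(=O)(=O)N[C@@H](CC(=O)NC(C)(C)C)C(=O)NCCNC(=O)c2cc(Cl)ccn2)cc1`, > 11100 nM
compound 2, `Cc1ccc(S(=O)(=O)N[C@@H](CC(=O)NC(C)(C)C)C(=O)NCCNC(=O)c2ccccc2)cc1`, > 11100 nM

In an ADME assay on Karpas-1106P cells (Homo sapiens) for cytotoxicity (on this read-out lower numbers stand for an effect already at smaller amounts and higher numbers for an effect only at larger amounts of compound), compound 1 gives > 11100 nM, which is a limit of the assay rather than a number. Compound 2, which keeps the same core and differs only in the group on the carbonyl carbon, also gives > 11100 nM in this assay, again a limit. The step that the two limits leave unreadable from compound 1 to compound 2 therefore cannot be read. Both values sit at the limit of > 11100 nM in this assay, at which 2 of the 2 values shown sit.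

Compound 3, `Cc1ccc(S(=O)(=O)N[C@@H](CC(=O)NC(C)(C)C)C(=O)NCCNC(=O)c2cc(C)ccc2F)cc1`, has not yet been measured in this assay. It differs from compound 2 by 2-fluoro-5-methylphenyl in place of phenyl on a carbonyl carbon. Among the measured compounds shown here, the only measured step of this kind, from compound 1 to compound 2, changes the same carbonyl-bound group and is unreadable, so no direction can be drawn from it. The expectation is that compound 3 stays near the limit, with an expected step that the limit leaves unreadable from compound 2 to compound 3. Compound 3 is therefore estimated at 15000 nM, between 7000 nM and 40000 nM.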

Compound 3, half-maximal effective concentration: > 11100 nM
Compound 3 ended at the assay's limit; the forecaster's own chance of this, stated with the estimate: 85%; the middle value is on the limit's open side.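

All the values are limits, so no step among compound 1, compound 2 and compound 3 can be read in this assay: the limit of > 11100 nM in this assay, at which 3 of the 3 values shown sit.

The compounds shown leave open whether the group on the carbonyl carbon changes cytotoxicity at all, and at what concentration any of them would show an effect.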